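This account rests on a few compounds, and the source may have more. Where it says the series, first, only, none or still open, it means among the compounds named here.

Measured so far in an ADME assay on microsomes from liver (Mus musculus) for metabolic stability, read by LC-MS; on this read-out lower numbers stand for slow clearance and higher numbers for fast clearance:

compound 1, `CC1CCC(NC(=O)c2cc3c(Cl)cc(Cl)cc3[nH]2)CC1`, gives 37 mL.min-1.g-1
compound 2, `CC1CCC(NC(=O)c2cc3ccc(Cl)cc3[nH]2)CC1`, gives 433 mL.min-1.g-1
compound 3, `CC1CCC(NC(=O)c2cc3cccc(Cl)c3[nH]2)CC1`, gives 1040 mL.min-1.g-1

The three measured compounds share the same amide and the same saturated ring and differ only in the chloro pattern on the shared core. Compound 3 stands highest of the three numbers; compound 2 is nearer to it and compound 1 is far below both. Compound 2 and compound 3 have the same atoms joined differently; the difference between the two cores is not broken down here.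

One change is seen twice. From compound 2 to compound 1 it is chloro in place of hydrogen on an aromatic carbon, and in this assay it gave a 12-fold lower number from compound 2 to compound 1 (1.07 log units; beyond the scatter). From compound 3 to the unmeasured compound 4, `CC1CCC(NC(=O)c2cc3cc(Cl)cc(Cl)c3[nH]2)CC1`, the change is chloro in place of hydrogen on an aromatic carbon. It is the same kind of change, not the same: in compound 1 the entering chloro is ortho to a fused ring, meta to a chloro group and meta to a fused ring, whereas in compound 4 it is meta to a chloro group, meta to a fused ring and para to a fused ring.

For the measured compounds named here, for compound 4 the step is expected to be a 3.0-fold lower number from compound 3 to compound 4 (0.47 log units; beyond the scatter), smaller than the earlier one because the earlier step of a 12-fold lower number from compound 2 to compound 1 (1.07 log units; beyond the scatter) was made at a different place and only one such pair is available. Compound 4 is therefore estimated at 350 mL.min-1.g-1, with a likely range from 120 mL.min-1.g-1 to 1000 mL.min-1.g-1.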

Compound 4, intrinsic clearance in microsomes: 187 mL.min-1.g-1
Estimate against measurement, compound 4: 1.9-fold (0.27 log units) above, within the range that was stated.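

In this assay, chloro in place of hydrogen on an aromatic carbon gave a 5.6-fold lower number from compound 3 to compound 4 (0.75 log units; beyond the scatter), so the number fell on both cores where this change can be read. The size of the step also carried over within the limits of these data, and the two steps cannot be told apart: the same change on two cores in this assay, a 12-fold lower number (1.07 log units; beyond the scatter) from compound 2 to compound 1 and a 5.6-fold lower number (0.75 log units; beyond the scatter) from compound 3 to compound 4, 2.1-fold (0.32 log units) apart, within the scatter of two such steps. For the compounds shown here, this rests on only two pairs, however, and the entering chloro and the chloro already present sit at different places in them, so the effect of the place of substitution cannot be separated from that of the core, and no general rule for other positions or other cores follows.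

Going by these compounds, it remains open whether another group on the same aromatic carbon, such as fluoro, methoxy or nitrile, would lower the number as chloro does, or whether the step depends on chloro itself. The compounds shown also leave open how far the same step carries when the methyl on the saturated ring gives way to a hydroxyl, an amine or a carboxylic acid, or when the amide itself is replaced.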